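Methylating the Ring Amine of the Weakest Analogue

The source may hold more compounds than are shown below. What is called first, only, known or untested is meant among the compounds shown, and "the series" means these compounds.

Compound 1 `CCn1cc(-c2nc3ccccc3o2)c(=O)c2cc(F)c(N3CCN(C)CC3)cc21`: 2000 nM
Compound 2 `CCn1cc(-c2nc3ccc([N+](=O)[O-])cc3[nH]2)c(=O)c2cc(F)c(N3CCN(C)CC3)cc21`: 4400 nM
Compound 3 `CCn1cc(-c2nc3ccc(N)cc3[nH]2)c(=O)c2cc(F)c(N3CCNCC3)cc21`: 92100 nM

In a functional assay on Bel-7402 cells (Homo sapiens) for cytotoxicity, read by MTT assay, with a stated time of 48 h (on this read-out higher numbers stand for weaker inhibition and lower numbers for stronger inhibition), compound 3 gives 92100 nM, the highest of the three numbers; compound 2 and compound 1 both sit far lower, each beyond the scatter. Compound 4 `CCn1cc(-c2nc3ccc(N)cc3[nH]2)c(=O)c2cc(F)c(N3CCN(C)CC3)cc21` differs from compound 3 in one place: methyl in place of hydrogen on an amine nitrogen in a ring. Read one bond further out, piperazin-1-yl becomes 4-methylpiperazin-1-yl, the group that compound 1 and compound 2 carry alongside their other differences. Within the data shown here, no measured pair shows this change by itself, so its size is not known from these data. A downward step of moderate size is expected, a 3.1-fold lower number from compound 3 to compound 4 (0.49 log units; beyond the scatter), though it may well stay within the scatter. Compound 4 is estimated at about 30000 nM, with a range from 8000 nM to 90000 nM.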

Compound 4, half-maximal inhibitory concentration: > 50000 nM
Compound 4 was reported as a limit; the forecaster's own chance of this, stated with the estimate: 5%; middle value at least 1.6-fold (0.22 log units) away from the limit.
By their numbers in this assay, from the lowest: compound 1; then compound 2; then compound 3.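

Compound 4 is reported only as a limit, > 50000 nM, so its step from compound 3 cannot be read. With 4-methylpiperazin-1-yl common to the pairs, amino in place of nitro on an aromatic carbon gives an at least 11-fold higher number from compound 2 to compound 4 (1.05 log units; beyond the scatter), and the exchange of the larger group on an aromatic carbon gives an at least 25-fold higher number from compound 1 to compound 4 (1.39 log units; beyond the scatter). Methyl on the ring amine nitrogen therefore does not bring this amino compound down to the numbers of the other two. As far as these compounds go, whether methyl shifts the number at all remains open, as does the effect of an ethyl or acetyl group on that nitrogen.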